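The source may report more compounds than this note shows. Statements on the series, on what has been measured and on what is new or still open speak of the compounds shown alone.

Measured in a functional assay on NCI-H460 cells (Homo sapiens) for cytotoxicity, read by sulforhodamine B assay, with a stated time of 3 days; on this read-out higher numbers stand for weaker inhibition and lower numbers for stronger inhibition:
Compound 1 `O=Cc1cn(Cc2ccc(Cl)cc2)c2ccc(F)cc12`: 290 nM
Compound 2 `OCc1cn(Cc2ccc(Br)cc2)c2ccccc12`: 31 nM
Compound 3 `OCc1cn(Cc2cccc(C(F)(F)F)c2)c2ccccc12`: 39 nM

In this assay compound 2 gives 31 nM and compound 3 gives 39 nM, two numbers that lie within the scatter of each other. Compound 1 gives 290 nM, a number higher than that of compound 2 by a margin well beyond the scatter.

Compound 4 `O=[N+]([O-])c1ccc(Cn2cc(CO)c3ccccc32)cc1` has not yet been measured in this assay. It departs from compound 2 by nitro in place of bromo on an aromatic carbon. For the measured compounds named here, no two measured compounds differ in one place only, so the data hold no direct step for this change. The nearest guide is compound 3, which carries trifluoromethyl rather than bromo and gives 39 nM. A small move toward weaker inhibition is expected, an estimated 1.9-fold higher number from compound 2 to compound 4 (0.29 log units; within the scatter). For compound 4 the estimated value is 60 nM, with an expected range of 20 nM to 200 nM.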

Compound 4, half-maximal inhibitory concentration: 79 nM
Compound 4: middle estimate off by 1.3-fold (0.12 log units), on the low side; measured number inside the range.
By their numbers in this assay, from the lowest: compounds 2 and 3 (each within the scatter of the next); then compound 4; then compound 1.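

In this assay, for the compounds shown here, the change from bromo to nitro on this aromatic carbon, para to a large group, provides the first direct step at this position: a 2.5-fold higher number from compound 2 to compound 4 (0.41 log units; beyond the scatter). This step is beyond the scatter but modest, so replacing a single bromine with a group of three heavy atoms, including two hydrogen-bond acceptors, weakens inhibition without abolishing it. No measurement shown here accounts for the step.

On these data alone, whether an amine, a carboxylic acid or a nitrile on the same carbon would resemble bromo or nitro remains open. Also unresolved is whether the step would hold on a core like that of compound 1, whose carbonyl and added fluoro separate it from compound 2 in more than one place.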